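Replacing the Carbamate Chain End with a Hydroxyl

The source may report more compounds than this note shows. Statements on the series, on what has been measured and on what is new or still open speak of the compounds shown alone.

Compound 1, `CC(C)(C)OC(=O)NCCCNC(=O)CN1CN(c2ccccc2)C2(CCN(C(=O)c3ccc(C4CCCCC4)cc3)CC2)C1=O`: 6000 nM
Compound 2, `CC(C)(C)OC(=O)NCCCNC(=O)CN1CN(c2ccccc2)C2(CCN(C(=O)c3ccc(C(C)(C)C)cc3)CC2)C1=O`: 4500 nM
Compound 3, `CC(C)(C)c1ccc(C(=O)N2CCC3(CC2)C(=O)N(CC(=O)NCN)CN3c2ccccc2)cc1`: 26500 nM

In an assay on HEK293 cells for displacement of a labelled ligand from NPC1-like intracellular cholesterol transporter 1 (Homo sapiens) (on this read-out higher numbers stand for weaker inhibition and lower numbers for stronger inhibition), compound 1 stands second highest of the three numbers. Its nearest neighbour is compound 2, reached by a 1.3-fold lower number from compound 1 to compound 2 (0.12 log units; within the scatter), which is within the scatter. Its furthest neighbour is compound 3, whose number is beyond the scatter above that of compound 1.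

Compound 4, `O=C(CN1CN(c2ccccc2)C2(CCN(C(=O)c3ccc(C4CCCCC4)cc3)CC2)C1=O)NCCCCO`, has not yet been measured. Relative to compound 1 it carries the change (hydroxymethyl in place of (tert-butoxycarbonyl)amino on a saturated chain carbon, three bonds along the chain from an amide-type nitrogen).

Going by the values given here, the only measured step that touches the same chain is a 5.9-fold higher number from compound 2 to compound 3 (0.77 log units; beyond the scatter), in which the (tert-butoxycarbonyl)amino end was lost together with part of the chain and the number rose. The change to compound 4 also removes the (tert-butoxycarbonyl)amino group but keeps the chain length and adds a hydroxyl, so a smaller movement in the same direction is expected in this assay: a 2.0-fold higher number from compound 1 to compound 4 (0.30 log units; within the scatter). Compound 4 is therefore estimated at 12000 nM, with a range from 5000 nM to 30000 nM.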

Compound 4, half-maximal inhibitory concentration: 10300 nM
Compound 4: middle estimate off by 1.2-fold (0.07 log units), on the high side; low and high end bracket the measured number.
By their numbers in this assay, from the lowest: compounds 2, 1 and 4 (each within the scatter of the next, the first and the last beyond it); then compound 3.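

In this assay, putting the 4-hydroxybutyl end in place of the 3-((tert-butoxycarbonyl)amino)propyl end gives a 1.7-fold higher number from compound 1 to compound 4 (0.23 log units; within the scatter) and so stays inside the scatter, which shows that this chain need not end in the (tert-butoxycarbonyl)amino group for the number to hold. Going by these compounds alone, the only earlier step on this chain, a 5.9-fold higher number from compound 2 to compound 3 (0.77 log units; beyond the scatter), lost that group and shortened the chain together; the new step keeps the chain length and shows that exchanging the end alone gives no change beyond the scatter. No measurement given here accounts for this result.

On these data alone, whether an amine, a carboxylic acid or a longer chain at this position would also stay within the scatter remains open. So does whether the hydroxyl end would behave alike with the tert-butyl group of compound 2 in place of the cyclohexyl group.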